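Sulfamate Series: From Compound 1 to Compound 4

This account rests on a few compounds, and the source may have more. Where it says the series, first, only, none or still open, it means among the compounds named here.

Three sulfamate-bearing compounds have been measured in an assay on HEK293 cells for inhibition of Steryl-sulfatase (Homo sapiens), tested at 0.1 uM; on this read-out lower numbers stand for a weaker effect and higher numbers for a stronger effect at the one concentration tested. Compound 1 `CN(C)CCN(CCN(C)C)c1ccc(C(=O)N2CCc3ccc(OS(N)(=O)=O)cc3C2)cc1` gives 3.8%, the second highest of the three numbers. Compound 2 `CCN(Cc1ccccc1)Cc1ccc(CN2CCc3ccc(OS(N)(=O)=O)cc3C2)cc1` gives 1%, a number within the scatter of compound 1. Compound 3 `NS(=O)(=O)Oc1ccc2c(c1)CN(C(=O)c1cccc(N(Cc3ccccc3)Cc3ccco3)c1)CC2` gives 27.5%, a number beyond the scatter above compound 1.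

Compound 4 `CCN(Cc1cccnc1)c1ccc(C(=O)N2CCc3ccc(OS(N)(=O)=O)cc3C2)cc1` has not yet been measured. It differs from compound 1 at one place: ethyl((pyridin-3-yl)methyl)amino in place of bis(2-(dimethylamino)ethyl)amino on an aromatic carbon Here ethyl((pyridin-3-yl)methyl)amino stands where bis(2-(dimethylamino)ethyl)amino stood, on an aromatic carbon, para to a large group.

Among the measured compounds shown here, no measured pair shows a single change of this kind, so the account rests on the three numbers alone. In this assay compound 4 is expected to give 10%, with a range from 0% to 28%. The step from compound 1 to compound 4 is estimated at a number 6.2 percentage points higher from compound 1 to compound 4 (within the scatter), a size that does not go beyond the usual scatter.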

Compound 4, a percentage reported as inhibition, at one concentration (the size of the read-out at that concentration, not a potency): 35.7%
Estimate against measurement, compound 4: 25.7 percentage points below; measured number outside the range, above it.
By their numbers in this assay, from the lowest: compounds 2 and 1 (each within the scatter of the next); then compounds 3 and 4 (each within the scatter of the next).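

In this assay, ethyl((pyridin-3-yl)methyl)amino in place of bis(2-(dimethylamino)ethyl)amino gives a number 31.9 percentage points higher from compound 1 to compound 4 (beyond the scatter) at this aromatic carbon, para to a large group. Among the compounds shown here, this is the first single change, and it shows that the read-out responds to what stands at this position. No measurement shown gives a reason for the rise.

The compounds shown leave open whether a phenyl ring in place of the pyridin-3-yl ring, or a methyl in place of the ethyl, would keep this level. They also leave open which part of the entering group carries the step.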